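Stretching a Short Chain, One Carbon at a Time

The source may hold more compounds than are shown below. What is called first, only, known or untested is meant among the compounds shown, and "the series" means these compounds.

Of the compounds shown here, three that share a common core have been tested in a functional assay on A2780 cells (Homo sapiens) for antiproliferative activity, read by MTT assay, with a stated time of 48 h; on this read-out higher numbers stand for weaker inhibition of growth and lower numbers for stronger inhibition of growth. Compound 1 `COC(=O)N1N=C(c2ccccc2)CC1c1cc(OC)c(OC)c(OC)c1` is the smallest of them. In this assay compound 1 gives 2770 nM. Compound 2 `CCOC(=O)N1N=C(c2ccccc2)CC1c1cc(OC)c(OC)c(OC)c1` carries one change relative to compound 1: methyl in place of hydrogen on a saturated chain carbon bound to an oxygen next to a carbonyl group. In this assay compound 2 gives 6720 nM, so that a 2.4-fold higher number from compound 1 to compound 2 (0.38 log units; beyond the scatter). Compound 3 `CCOC(=O)N1N=C(c2ccc(OC)cc2)CC1c1cc(OC)c(OC)c(OC)c1` differs from compound 2 by methoxy in place of hydrogen on an aromatic carbon. In this assay compound 3 gives 9270 nM, and a 1.4-fold higher number from compound 2 to compound 3 (0.14 log units; within the scatter). How the core of compound 1 and the core of compound 3 differ is not broken down here.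

Compound 4 `CCCOC(=O)N1N=C(c2ccc(OC)cc2)CC1c1cc(OC)c(OC)c(OC)c1` has not yet been measured. Relative to compound 3 its change is methyl in place of hydrogen on a saturated chain carbon, two bonds along the chain from an oxygen next to a carbonyl group. Within the data shown here, this is the same kind of change as the one between compound 1 and compound 2, but not the same: there the new methyl sat on a saturated chain carbon bound to an oxygen next to a carbonyl group, here it sits two bonds along the chain from that oxygen. Among the measured compounds shown here, the one measured step of this kind, a 2.4-fold higher number from compound 1 to compound 2 (0.38 log units; beyond the scatter), made the number rise. Compound 4 is therefore expected to show a 1.6-fold higher number from compound 3 to compound 4 (0.21 log units; within the scatter) in this assay, a modest rise resting on that earlier step. Compound 4 is estimated at 15000 nM, between 6000 nM and 40000 nM.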

Compound 4, concentration for 50% growth inhibition: 11700 nM
Beside the measured number, compound 4's estimate is 1.3-fold (0.11 log units) above it, within the range that was stated.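

Adding one more carbon to the chain, ethyl to propyl, gives a 1.3-fold higher number from compound 3 to compound 4 (0.10 log units; within the scatter) in this assay, so this step alone cannot be told apart from no change at all. Set beside the earlier step, the new one does not differ from it by more than these measurements can resolve: the same change on two cores in this assay, a 2.4-fold higher number (0.38 log units; beyond the scatter) from compound 1 to compound 2 and a 1.3-fold higher number (0.10 log units; within the scatter) from compound 3 to compound 4, 1.9-fold (0.28 log units) apart, within the scatter of two such steps. Among these compounds, this shows that nothing here separates the two cores for this kind of change, but it does not show that the change acts the same way on both, since there are only two pairs, just one of the steps lies beyond the scatter, and the new methyl sits at a different place on the chain in each pair.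

The compounds shown leave open whether the rise seen so far continues with a longer chain such as butyl, or what a branched chain such as isopropyl would do in the same place. They also leave open how a chain ending in an amine or a carboxylic acid would behave, and whether a propyl chain on the core of compound 1 would follow the same course.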